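The source may hold more compounds than are shown below. What is called first, only, known or untested is meant among the compounds shown, and "the series" means these compounds.

- Compound 1 `O=C1/C(=C/c2cccnc2)CN(S(=O)(=O)c2ccc(C(F)(F)F)cc2)C/C1=C\c1ccccc1C(F)(F)F` gives 1710 nM
- Compound 2 `N#Cc1ccc(S(=O)(=O)N2C/C(=C\c3cccnc3)C(=O)/C(=C/c3ccccc3C(F)(F)F)C2)cc1` gives 5060 nM

In a functional assay on HepG2 cells (Homo sapiens) for cytotoxicity, read by MTT assay, with a stated time of 24 h (on this read-out lower numbers stand for stronger inhibition and higher numbers for weaker inhibition), compound 2 stands highest of the two, with 5060 nM. Compound 3 `CC(=O)Nc1ccc(S(=O)(=O)N2C/C(=C\c3cccnc3)C(=O)/C(=C/c3ccccc3C(F)(F)F)C2)cc1` differs from it by acetamido in place of cyano on an aromatic carbon, para to a large group. Going by the values given here, only one measured step bears on this carbon: a 3.0-fold higher number from compound 1 to compound 2 (0.47 log units; beyond the scatter), modest and beyond the scatter. That single step gives no direction for acetamido, so no step beyond the scatter is firmly expected in this assay. The estimated value for compound 3 is 4000 nM, within an expected range of 1500 nM to 12000 nM. This estimate means an expected 1.3-fold lower number from compound 2 to compound 3 (0.10 log units; within the scatter).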

Compound 3, half-maximal inhibitory concentration: 4330 nM
Beside the measured number, compound 3's estimate is 1.1-fold (0.03 log units) below it; the measured number falls inside the stated range.
By their numbers in this assay, from the lowest: compound 1; then compounds 3 and 2 (each within the scatter of the next).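

In this assay, the change from cyano to acetamido on this aromatic carbon, para to a large group, gives a 1.2-fold lower number from compound 2 to compound 3 (0.07 log units; within the scatter) and so leaves the number within the scatter, although the larger group enters here. Acetamido in place of trifluoromethyl gives a 2.5-fold higher number from compound 1 to compound 3 (0.40 log units; beyond the scatter) and thus a change beyond the scatter, so among these three groups, trifluoromethyl alone stands apart, with the lower number. Nothing given here accounts for these numbers.

From the compounds shown here alone, whether an amine, a carboxylic acid or a simple methoxy group at this carbon would fall with compound 1 or with compound 3 remains open.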